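Extending the Chain on a Weak Hydroxy Analogue

The source may report more compounds than this note shows. Statements on the series, on what has been measured and on what is new or still open speak of the compounds shown alone.

Of the compounds shown here, three sharing one core have been measured. Compound 1 `Fc1cccc(Nc2nc3nonc3nc2Nc2ccccc2F)c1` gives 190 nM in an assay on mitochondria from L6 cells (Rattus norvegicus) for activation, with a stated time of 90 min; a higher number here means that more compound is needed for the effect, a lower number that less compound is needed. Compound 2 `CCc1ccc(Nc2nc3nonc3nc2O)cc1` gives 10700 nM in this assay, and compound 3 `CCc1ccc(Nc2nc3nonc3nc2O)c(F)c1` gives 6700 nM in this assay. On these numbers compound 3 stands second highest of the three: the change a 1.6-fold lower number from compound 2 to compound 3 (0.20 log units; within the scatter) lies within the scatter, whereas the gap to compound 1 is wide and beyond it.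

Compound 4 `CCCCCCc1ccc(Nc2nc3nonc3nc2O)c(F)c1` differs from compound 3 by butyl in place of hydrogen on a saturated chain carbon, two bonds along the chain from an aromatic carbon. Within the data shown here, none of the measured steps touches a change of this kind; the only step available concerns a fluoro substituent and says nothing about chain length. The account therefore lacks any anchor for the direction of the step, and the expectation is a number close to that of compound 3 with a broad range on either side.

Compound 4 is thus expected to give 4000 nM in this assay, between 700 nM and 20000 nM, the estimate corresponding to a 1.7-fold lower number from compound 3 to compound 4 (0.22 log units; within the scatter).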

Compound 4, half-maximal effective concentration: 3300 nM
Compound 4: middle estimate off by 1.2-fold (0.08 log units), on the high side, within the range that was stated.
By their numbers in this assay, from the lowest: compound 1; then compound 4; then compounds 3 and 2 (each within the scatter of the next).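

In this assay, butyl in place of hydrogen on a saturated chain carbon, two bonds along the chain from an aromatic carbon, gives a 2.0-fold lower number from compound 3 to compound 4 (0.31 log units; beyond the scatter). Among these compounds, this is the first measured change at this position, and it shows that going from ethyl to hexyl is tolerated and brings a modest gain, whereas the fluoro change, a 1.6-fold lower number from compound 2 to compound 3 (0.20 log units; within the scatter), stayed within the scatter. Nothing available here bears on why the number moves with this change.

From the compounds shown here alone, a single step gives no trend, so it remains open whether a shorter chain such as propyl or a longer chain such as octyl would continue the change or reverse it. Also open, going by these compounds, are whether an amine or a carboxylic acid at the chain end would keep the gain, and whether hexyl gives the same step without the fluoro.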